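The source may report more compounds than this note shows. Statements on the series, on what has been measured and on what is new or still open speak of the compounds shown alone.

In a functional assay (Pituitary gland cell) with Rattus norvegicus as the target (a higher number here means that more compound is needed for the effect, a lower number that less compound is needed), compound 1 `CNC(=O)Nc1ccccc1-c1ccc(CN2C(=O)[C@H](NC(=O)CC(C)(C)N)CCc3ccccc32)cc1` gives 50 nM and compound 2 `CNC(=O)NCc1ccccc1-c1ccc(CN2C(=O)[C@H](NC(=O)CC(C)(C)N)CCc3ccccc32)cc1` gives 6 nM. Compound 3 `CC(C)(N)CC(=O)N[C@@H]1CCc2ccccc2N(Cc2ccc(-c3ccccc3CN)cc2)C1=O` gives only a limit of this assay, > 1000 nM, not a measured number (the limit of > 1000 nM in this assay, at which 1 of the 3 values shown sits). On the numbers shown, compound 3 stands weakest of the three. Compound 4 `CC(C)(N)CC(=O)N[C@@H]1CCc2ccccc2N(Cc2ccc(-c3ccccc3C(N)=O)cc2)C1=O` differs from compound 3 by carbamoyl in place of aminomethyl on an aromatic carbon. Among the measured compounds shown here, two measured steps bear on this change: an at least 20-fold higher number from compound 1 to compound 3 (1.30 log units; beyond the scatter) and an at least 160-fold higher number from compound 2 to compound 3 (2.22 log units; beyond the scatter), both large, and both end in the aminomethyl that compound 3 carries. Compound 4 puts a carbamoyl, with its carbonyl, back on that aromatic carbon, and a lower number than the limit of compound 3 is therefore expected, namely an at least 3.3-fold lower number from compound 3 to compound 4 (0.52 log units; beyond the scatter). For compound 4 the estimate in this assay is 300 nM, expected to lie between 50 nM and 3000 nM.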

Compound 4, concentration for half-maximal effect: 80 nM
Compound 4: middle estimate off by 3.8-fold (0.57 log units), on the high side, and the stated range covers the measured number.
By their numbers in this assay, from the lowest: compound 2; then compounds 1 and 4 (each within the scatter of the next). At a limit, above all of these: compound 3.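

Compound 3 carries only a limit, not a number: the limit of > 1000 nM in this assay, at which 1 of the 4 values shown sits. Carbamoyl in place of aminomethyl gives an at least 12-fold lower number from compound 3 to compound 4 (1.09 log units; beyond the scatter), so on this aromatic carbon a methylcarbamoyl is not required for activity. Carbamoyl stays level with (methylcarbamoyl)amino, with a 1.6-fold higher number from compound 1 to compound 4 (0.20 log units; within the scatter), but falls short of ((methylcarbamoyl)amino)methyl, with a 13-fold higher number from compound 2 to compound 4 (1.12 log units; beyond the scatter).

The compounds shown leave open whether the carbonyl or the nitrogen of the carbamoyl matters more here. A carboxylic acid or a methyl ketone on this carbon would separate the two.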